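Piperazinyl amide replacing a carboxyethyl amide in spiro compounds

The compounds below may be only part of what the source reports. "The series", "measured", "known", "first", "only" and "open" are said of these compounds alone.

Measured compounds, in an assay on HEK293 cells for displacement of a labelled ligand from NPC1-like intracellular cholesterol transporter 1 (Homo sapiens); a lower number here means a stronger inhibitor, a higher number a weaker inhibitor:
compound 1, `CC(C)(C)OC(=O)NC1CCN(C(=O)CN2CN(c3ccccc3)C3(CCN(C(=O)c4ccc(C(C)(C)C)cc4)CC3)C2=O)CC1`, 8300 nM
compound 2, `CC(C)(C)c1ccc(C(=O)N2CCC3(CC2)C(=O)N(CC(=O)NCCC(=O)O)CN3c2ccccc2)cc1`, 11400 nM
compound 3, `CC1(C)CC(OC(=O)CN2CN(c3ccccc3)C3(CCN(C(=O)c4ccc(C5CCCCC5)cc4)CC3)C2=O)CC(C)(C)N1`, 600 nM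

All three share one core and differ in the amide side chain and in the group on the outer benzoyl ring. Compound 2 has the highest number of the three. Its nearest neighbour is compound 1, whose value lies within the usual scatter, so no order between these two can be claimed. Compound 3 gives a number far lower than compound 2, well beyond the scatter, but it differs from compound 2 in more than one place, so its two values show a gap and nothing more.

The unmeasured compound 4, `CC(C)(C)c1ccc(C(=O)N2CCC3(CC2)C(=O)N(CC(=O)N2CCNCC2)CN3c2ccccc2)cc1`, is compound 2 with one change: piperazin-1-yl in place of (2-carboxyethyl)amino on a carbonyl carbon. Among the compounds with values here, no measured pair shows this exact change, so the step from compound 2 to compound 4 can only be expected, not read off. Because compound 3 gives 600 nM with a ring-bearing amine in place of an acid, a moderate downward step toward lower numbers is expected, a 3.8-fold lower number from compound 2 to compound 4 (0.58 log units; beyond the scatter). For compound 4 the expected value is 3000 nM, estimated to fall between 800 nM and 12000 nM.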

Compound 4, half-maximal inhibitory concentration: 22000 nM
Estimate against measurement, compound 4: 7.3-fold (0.87 log units) below; measured number above the stated range.
By their numbers in this assay, from the lowest: compound 3; then compounds 1, 2 and 4 (each within the scatter of the next, the first and the last beyond it).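

In this assay, putting piperazin-1-yl in place of (2-carboxyethyl)amino on a carbonyl carbon gives a 1.9-fold higher number from compound 2 to compound 4 (0.29 log units; within the scatter), so the two compounds cannot be told apart. Within the data shown here, this is the first pair here that differs in one place only, and it shows that this position can carry either a open chain ending in a carboxylic acid or a six-membered ring with two nitrogens, both of 6 heavy atoms, with no readable shift in the number. Nothing measured here explains why the swap leaves the number within the scatter.

All other pairs among these compounds differ in more than one place, so their steps cannot be read, and the far lower number of compound 3 remains unassigned to either its side chain or the cyclohexyl group on its outer benzoyl ring. Also open, as far as these compounds go, is whether a piperazine carrying a methyl group, a piperidine, or a longer chain ending in a carboxylic acid on the same carbonyl carbon would move the number beyond the scatter.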